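Swapping Phenylsulfonyl for a Carbonyl Group: Compound 4

The source may hold more compounds than are shown below. What is called first, only, known or untested is meant among the compounds shown, and "the series" means these compounds.

Measured compounds in a functional assay on MCF7 cells (Homo sapiens) for inhibition, read by MTT assay, with a stated time of 48 h; on this read-out higher numbers stand for weaker inhibition and lower numbers for stronger inhibition:
- Compound 1 `COc1ccc(CN(c2cc(OC)c(OC)c(OC)c2)S(=O)(=O)c2ccccc2)cc1`: compound 1 gives > 50000 nM, which is a limit of the assay.
- Compound 2 `COc1cc(N(Cc2nc3ccccc3[nH]2)S(=O)(=O)c2ccccc2)cc(OC)c1OC`: compound 2 gives 27300 nM.
- Compound 3 `COc1ccc(N(Cc2nc3ccccc3[nH]2)S(=O)(=O)c2ccc(C)cc2)cc1`: compound 3 gives > 50000 nM, which is a limit of the assay.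

For the measured compounds named here, compound 2 is the only compound with a number in this assay. The two other values sit at the limit of > 50000 nM in this assay, at which 2 of the 3 values shown sit. Going by the values given here, the one measured step, an at least 1.8-fold lower number from compound 1 to compound 2 (0.26 log units; that floor lies within the scatter), moves from a limit to a number and rests on a change at the chain carbon, not at the nitrogen.

Compound 4 `COc1cc(N(Cc2nc3ccccc3[nH]2)C(=O)c2ccc(C)cc2)cc(OC)c1OC` differs from compound 2 in one place: (4-methylphenyl)carbonyl in place of phenylsulfonyl on a nitrogen on an aromatic ring. Among the compounds with values here, no measured step involves an exchange of this kind, so none bears on it. Within the data shown here, the only step known concerns a different part of the structure, and the remaining values are limits. With nothing pointing in either direction, the expectation is a change no larger than the scatter, leaning toward a weaker number, since two of three shown values already sit at the limit.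

Compound 4 is therefore estimated at 35000 nM in this assay, with a range from 12000 nM to 60000 nM, meaning an expected step of a 1.3-fold higher number from compound 2 to compound 4 (0.11 log units; within the scatter).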

Compound 4, half-maximal inhibitory concentration: 49300 nM
For compound 4 the middle estimate is 1.4-fold (0.15 log units) below the measured one; low and high end bracket the measured number.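

In this assay, exchanging phenylsulfonyl for (4-methylphenyl)carbonyl on the nitrogen gives a 1.8-fold higher number from compound 2 to compound 4 (0.26 log units; within the scatter), so this exchange does not separate the two compounds beyond the usual noise of the measurement. Where the earlier step concerned the chain carbon, this one touches the group on the nitrogen itself, and it shows that a compound with a carbonyl there, and no sulfur, still gives a number rather than a limit; the single exchange, however, alters two features at once, the link to the nitrogen and a methyl on the ring. Both numbers also lie at the weak end of the read-out, where little room remains before values stop being numbers at all: the limit of > 50000 nM in this assay, at which 2 of the 4 values shown sit.

The compounds shown leave open whether the carbonyl and the methyl each matter or simply offset one another, a question that plain phenylcarbonyl on this nitrogen could address. They also leave open whether a quite different group there, such as an acetyl or a ring bearing an amine or a carboxylic acid, would give a clearly lower number.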